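The source may hold more compounds than are shown below. What is called first, only, known or untested is meant among the compounds shown, and "the series" means these compounds.

Measured compounds:
compound 1, `C/N=C(/NC#N)NCCCn1nc(-c2ccccc2)ccc1=O`, 40.5%
compound 2, `CC/N=C(\S)NCCCCCn1nc(-c2ccccc2)ccc1=O`, 66.4%
compound 3, `N#CNC(=N)NCCCCn1nc(-c2ccccc2)ccc1=O`, 61.2%

In a functional assay on the whole organism with Rattus norvegicus as the target, at a dose of 100 mg/kg (a lower number here means less inhibition, a higher number more inhibition at the dose given (going by the name of the read-out)), compound 2 gives 66.4%, the highest of the three numbers. Its nearest neighbour is compound 3 with 61.2%, and the gap a number 5.2 percentage points lower from compound 2 to compound 3 (within the scatter). Compound 1 sits furthest away at 40.5%, with a number 25.9 percentage points higher from compound 1 to compound 2 (beyond the scatter).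

Compound 4, `CN(C)/C(=N/CCCCCCn1nc(-c2ccccc2)ccc1=O)NC#N`, differs from compound 2 by a group of 9 heavy atoms (5 carbon, 4 nitrogen; no ring) in place of a group of 6 heavy atoms (3 carbon, 2 nitrogen, 1 sulfur; no ring), on a saturated chain carbon, five bonds along the chain from an aromatic nitrogen. The step from compound 1 to compound 2 bears on this, since there a group of 3 carbon and 4 nitrogen atoms was replaced by a sulfur-containing group and the number rose by a number 25.9 percentage points higher from compound 1 to compound 2 (beyond the scatter). Compound 4 moves back toward a nitrogen-rich group, here with 5 carbon and 4 nitrogen atoms, so a modest fall is expected, though compound 3 shows that such a group can also stay within the scatter of compound 2. Compound 4 is therefore expected to give 52%, a step of a number 14.4 percentage points lower from compound 2 to compound 4 (beyond the scatter), with a range from 32% to 72%.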

Compound 4, a percentage reported as inhibition, in the whole organism at one dose (the size of the read-out at that dose, not a potency): 58.4%
Estimate against measurement, compound 4: 6.4 percentage points below, and the stated range covers the measured number.
By their numbers in this assay, from the lowest: compound 1; then compounds 4, 3 and 2 (each within the scatter of the next).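

In this assay, exchanging the sulfur-containing group with 3 carbon, 2 nitrogen and 1 sulfur atoms for the larger group with 5 carbon and 4 nitrogen atoms, on a saturated chain carbon five bonds along the chain from an aromatic nitrogen, gives a number 8 percentage points lower from compound 2 to compound 4 (within the scatter). The sulfur-containing group is therefore not needed to keep the read-out at this level, and compound 4 joins compound 3 as a second nitrogen-rich example within the scatter of compound 2, while compound 1 goes against this with 40.5%. No measurement is available to explain why the read-out holds across this exchange.

The compounds shown leave open how the chain and end group contribute separately. They also leave open whether a simple amine or a carboxylic acid at the chain end would keep the read-out at this level.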